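Methyl on the hydroxy oxygen of compound 1

The source may report more compounds than this note shows. Statements on the series, on what has been measured and on what is new or still open speak of the compounds shown alone.

compound 1 `O=C(NCCCNc1cc(-c2cn(-c3ccccc3)nc2-c2cccc(O)c2)ccn1)Nc1ccc(F)cc1` gives 10700 nM
compound 2 `O=C(NCCCNc1cc(-c2cn(-c3ccccc3)nc2-c2cccc(O)c2)ccn1)Nc1cccc(C(F)(F)F)c1` gives 12300 nM

Among the measured compounds shown here, in a functional assay on CAKI-1 cells (Homo sapiens) for antiproliferative activity, read by sulforhodamine B assay, with a stated time of 48 h (a higher number here means a weaker inhibitor of growth, a lower number a stronger inhibitor of growth), compound 1 stands level with the only other measured compound. For the measured compounds named here, the single measured step is a 1.1-fold higher number from compound 1 to compound 2 (0.06 log units; within the scatter) and it concerns 3-(trifluoromethyl)phenyl in place of 4-fluorophenyl on an amide-type nitrogen, not the oxygen at issue here.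

Compound 3 `COc1cccc(-c2nn(-c3ccccc3)cc2-c2ccnc(NCCCNC(=O)Nc3ccc(F)cc3)c2)c1` keeps the rest of compound 1 and carries 3-methoxyphenyl instead of 3-hydroxyphenyl, methyl in place of hydrogen on an oxygen on an aromatic ring. Going by the values given here, no measured pair tests this change, so the step above bears on it only weakly and the range stays wide. In this assay no step beyond the scatter is expected, with a slight lean towards a higher number. Compound 3 is estimated at 14000 nM (expected range 6000 nM to 32000 nM). The expected step is a 1.3-fold higher number from compound 1 to compound 3 (0.12 log units; within the scatter) and remains an estimate.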

Compound 3, concentration for total growth inhibition: > 37000 nM
Compound 3 gave a limit, no number; the forecaster's own chance of this, stated with the estimate: 10%; middle value at least 2.6-fold (0.42 log units) from the limit.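

In this assay, methyl in place of hydrogen on an oxygen on an aromatic ring gives an at least 3.4-fold higher number from compound 1 to compound 3 (0.53 log units; beyond the scatter). Among the compounds shown here, compound 3 gives > 37000 nM, which is a limit of the assay and not a number: the limit of > 37000 nM in this assay, at which 1 of the 3 values shown sits. The earlier step, on an amide-type nitrogen, was a 1.1-fold higher number from compound 1 to compound 2 (0.06 log units; within the scatter), so the hydroxy oxygen is the first place in this short series where a single change lies beyond the scatter.

The compounds shown leave open whether the step depends on losing the hydrogen or on the entering methyl, and how far the number rises beyond the limit. An amine in place of the hydroxy, or an ethoxy group, would help separate these readings, and the same change on compound 2 would show whether the step carries over to the 3-(trifluoromethyl)phenyl partner.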